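Shortening the phenoxy chain on a saturated tail

This account rests on a few compounds, and the source may have more. Where it says the series, first, only, none or still open, it means among the compounds named here.

Compound 1 `O=C(O)c1csc([C@H]2CC[C@@H]3[C@@H](/C=C/CCCOc4ccccc4)[C@H](O)C[C@@H]3O2)n1` gives > 10000 nM, a limit of the assay. Compound 2 `O=C(O)c1csc([C@H]2CC[C@@H]3[C@@H](/C=C/CCOc4ccccc4)[C@H](O)C[C@@H]3O2)n1` gives 1900 nM. Compound 3 `O=C(O)c1csc([C@H]2CC[C@@H]3[C@@H](CCCOc4ccccc4)[C@H](O)C[C@@H]3O2)n1` gives > 10000 nM, again only a limit.

All values come from a functional assay on CHO cells for agonist activity at prostaglandin E2 receptor EP4 subtype (Homo sapiens), read by HTRF and cAMP accumulation, with a stated time of 30 min; on this read-out higher numbers stand for an effect only at larger amounts of compound and lower numbers for an effect already at smaller amounts. From compound 1 to compound 2 the change is phenoxy in place of phenoxymethyl on a saturated chain carbon, two bonds along the chain from a double-bonded chain carbon, and it brings an at least 5.2-fold lower number from compound 1 to compound 2 (0.72 log units; beyond the scatter). The difference between the cores of compound 1 and compound 3 is not broken down here. Compound 4 `O=C(O)c1csc([C@H]2CC[C@@H]3[C@@H](CCOc4ccccc4)[C@H](O)C[C@@H]3O2)n1` carries the same kind of change, (phenoxy in place of phenoxymethyl on a saturated chain carbon, two bonds along the chain from a saturated ring carbon), but at a place two bonds along the chain from a saturated ring carbon rather than from a double-bonded chain carbon. Since compound 3 sits at the limit (the limit of > 10000 nM in this assay, at which 2 of the 3 values shown sit), the expected step of an at least 2.0-fold lower number from compound 3 to compound 4 (0.30 log units; that floor lies within the scatter) is uncertain in size. Compound 4 is estimated at 5000 nM.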

Compound 4, half-maximal effective concentration: > 10000 nM
Compound 4 was reported as a limit (the forecaster's own chance of this, stated with the estimate: 40%); middle value at least 2.0-fold (0.30 log units) away from the limit.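

Compound 3 and compound 4 both sit at a limit, so no step between them can be read: the limit of > 10000 nM in this assay, at which 3 of the 4 values shown sit.

On these data alone, whether the shortening that helped from compound 1 to compound 2 also helps on the saturated chain stays open.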